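A few compounds are considered here, and "the series" means these few. Any claim that something is new, unique, unknown or untested is made for them only; others in the source may bear on it.

Measured compounds in a functional assay on MCF7 cells (Homo sapiens) for antiproliferative activity, read by MTT assay, with a stated time of 24 h, tested at 0.1 ug/mL; a lower number here means a stronger effect, a higher number a weaker effect of the compound at the concentration tested:

Compound 1, `O=Cc1cn(-c2ccccc2)nc1-c1ccc([N+](=O)[O-])cc1`: 96%
Compound 2, `O=Cc1cn(-c2ccccc2)nc1-c1ccc(Cl)cc1`: 90%
Compound 3, `COc1cc(/C=C/C(=O)C(=Cc2cn(-c3ccccc3)nc2-c2ccc([N+](=O)[O-])cc2)C(=O)/C=C/c2ccc(O)c(OC)c2)ccc1O`: 92%

Compound 3 stands among the three measured numbers with both neighbours within the scatter: compound 2 gives a number two points lower and compound 1 a number four points higher, so nothing in this set separates the three compounds from one another. Compound 3 carries the two extended enone arms on the shared core, whereas compound 1 and compound 2 are the bare aldehydes.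

Compound 4, `COc1cc(/C=C/C(=O)C(=Cc2cn(-c3ccccc3)nc2-c2ccc(Cl)cc2)C(=O)/C=C/c2ccc(O)c(OC)c2)ccc1O`, has not yet been measured in this assay. It differs from compound 3 in one place: chloro in place of nitro on an aromatic carbon. The same change has been seen once, on the aldehyde core, in the step from compound 1 to compound 2, which was a number 6 percentage points lower from compound 1 to compound 2 (within the scatter). That step is the only measured one that bears on the present change, and it stayed within the scatter.

On that single precedent the step from compound 3 to compound 4 is expected to be a number 4 percentage points lower from compound 3 to compound 4 (within the scatter), that is, no change beyond the scatter in either direction. Compound 4 is therefore estimated at 88%, with a likely range from 78% to 98%.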

Compound 4, a percentage reported as activity, at one concentration (the size of the read-out at that concentration, not a potency): 72%
Beside the measured number, compound 4's estimate is 16 percentage points above it; measured number outside the range, below it.
By their numbers in this assay, from the lowest: compound 4; then compounds 2, 3 and 1 (each within the scatter of the next).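

The change from 4-nitrophenyl to 4-chlorophenyl on the core with the two enone arms gives a number 20 percentage points lower from compound 3 to compound 4 (beyond the scatter) in this assay, and so this position, para to a large group, can carry a difference that stands clear of the scatter. The aldehydes had not shown this, since the same change there gave a number 6 percentage points lower from compound 1 to compound 2 (within the scatter), which left open whether the swap had any effect at all. Even so, the new step cannot be called larger than the earlier one, and the data do not show that the enone arms enlarge the effect of the change: the same change on two cores in this assay, a number 6 percentage points lower (within the scatter) from compound 1 to compound 2 and a number 20 percentage points lower (beyond the scatter) from compound 3 to compound 4, 14 percentage points apart, within the scatter of two such steps.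

The compounds shown carry only nitro and chloro at this position, so it remains open whether the step follows from chloro specifically or would also appear with another group there, such as bromo, methoxy or an amine. Every reading comes from a single concentration and a single cell line, which leaves open how compound 4 behaves at other concentrations and whether the step holds in other cells.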